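The source may report more compounds than this note shows. Statements on the series, on what has been measured and on what is new or still open speak of the compounds shown alone.

In a functional assay on the whole organism with Rattus norvegicus as the target (a higher number here means that more compound is needed for the effect, a lower number that less compound is needed), compound 1 `CCOC(=O)C(=O)Nc1cccc(N(C)C)c1C#N` gives 4.2 mg/kg and compound 2 `CCOC(=O)C(=O)Nc1ccc(N(C)C)cc1C#N` gives 2.4 mg/kg, two values within the usual scatter of each other. Compound 3 `CCOC(=O)C(=O)Nc1cccc(N)c1C#N` keeps the core of compound 1 but carries amino in place of dimethylamino on an aromatic carbon, ortho to a cyano group: amino in place of dimethylamino on an aromatic carbon. For the measured compounds named here, no pair of measured compounds differs in one place only, so nothing measured yet sizes this change. The expected step, a 1.1-fold lower number from compound 1 to compound 3 (0.02 log units; within the scatter), is none beyond the scatter, with no direction favoured. For compound 3 the estimate is 4 mg/kg, with an expected range from 1.5 mg/kg to 11 mg/kg.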

Compound 3, dose for half-maximal effect: 0.07 mg/kg
Beside the measured number, compound 3's estimate is 57-fold (1.76 log units) above it; measured number outside the range, below it.
By their numbers in this assay, from the lowest: compound 3; then compounds 2 and 1 (each within the scatter of the next).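

In this assay, this aromatic carbon, ortho to a cyano group, proves highly sensitive to the group it carries: amino in place of dimethylamino gives a 60-fold lower number from compound 1 to compound 3 (1.78 log units; beyond the scatter). Amino has fewer heavy atoms than dimethylamino and brings a hydrogen-bond donor, but this single change cannot show which difference matters. No evidence available here accounts for the size of the step. On these data alone, whether methylamino behaves more like amino or like dimethylamino stays open. So does whether amino in place of the dimethylamino group of compound 2 would give a similar step.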